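Removing one chloro from compound 1: an expectation

A few compounds are considered here, and "the series" means these few. Any claim that something is new, unique, unknown or untested is made for them only; others in the source may bear on it.

Measured in a functional assay on the whole organism (strain Swiss albino) with Mus musculus as the target, with a stated time of 0.5 h; a higher number here means that more compound is needed for the effect, a lower number that less compound is needed:
compound 1 `O=C(N/N=C/c1ccc(Cl)cc1Cl)Nc1cccc2ccccc12` — 300 mg/kg
compound 2 `COc1cc(/C=N/NC(=O)Nc2cccc3ccccc23)cc(OC)c1OC` — 100 mg/kg
compound 3 `C/C(=N\NC(=O)Nc1cccc2ccccc12)c1ccc(Cl)cc1` — 300 mg/kg

Compound 1 stands level with compound 3 at the digits given, the two together the highest numbers of the three, while compound 2 gives a number beyond the scatter lower than compound 1. Compound 4 `O=C(N/N=C/c1ccccc1Cl)Nc1cccc2ccccc12` has not yet been measured. It differs from compound 1 by hydrogen in place of chloro on an aromatic carbon, a change that reads, cut one bond further out, as 2,4-dichlorophenyl to 2-chlorophenyl. Going by the values given here, no measured pair shows this change, so nothing in the numbers points in either direction; a step within the scatter is expected. On that basis compound 4 is estimated at 300 mg/kg in this assay, with a range of 100 mg/kg to 1000 mg/kg, which means an expected step of no change at the digits printed from compound 1 to compound 4 (within the scatter).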

Compound 4, minimum effective dose: 300 mg/kg
Compound 4: middle estimate and measured number agree at the digits printed, within the range that was stated.
By their numbers in this assay, from the lowest: compound 2; then compounds 1, 3 and 4 (each within the scatter of the next).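

In this assay, going by these compounds alone, the change from 2,4-dichlorophenyl to 2-chlorophenyl gives no change at the digits printed from compound 1 to compound 4 (within the scatter) and so offers the first measured reading of this change. At this position, on an aromatic carbon meta to a chloro group and para to a large group, chloro and hydrogen cannot be told apart in this assay. Nothing among the available data offers an explanation for this result. The compounds shown leave open whether an amine or a carboxylic acid at this position would move the number, and whether the remaining chloro could also give way to hydrogen.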